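Cytotoxicity check on the amide aryl group: compound 4

The source may hold more compounds than are shown below. What is called first, only, known or untested is meant among the compounds shown, and "the series" means these compounds.

Compound 3 `Cn1cnnc1SCCc1nnc(SCC(=O)Nc2nc3ccccc3s2)o1` carries a 1,3-benzothiazol-2-yl group on the amide nitrogen of the shared core. In an ADME assay on NIH3T3 cells (Mus musculus) for cytotoxicity, read by MTT assay, with a stated time of 24 h (on this read-out higher numbers stand for weaker inhibition and lower numbers for stronger inhibition), compound 3 gives > 500 ug/mL, which is a limit of the assay and not a number. Compound 1 `Cn1cnnc1SCCc1nnc(SCC(=O)Nc2ccc([N+](=O)[O-])cc2)o1` in this assay gives > 500 ug/mL, again a limit. Compound 2 `Cn1cnnc1SCCc1nnc(SCC(=O)Nc2ccc(Cl)cc2)o1` in this assay gives > 500 ug/mL, also a limit. All three sit at the limit of > 500 ug/mL in this assay, at which 3 of the 3 values shown sit, so the steps from compound 1 to compound 2 a step that the two limits leave unreadable from compound 1 to compound 2, from compound 1 to compound 3 a step that the two limits leave unreadable from compound 1 to compound 3 and from compound 2 to compound 3 a step that the two limits leave unreadable from compound 2 to compound 3 cannot be read in size.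

Compound 4 `COc1ccc(NC(=O)CSc2nnc(CCSc3nncn3C)o2)cc1` differs from compound 3 by 4-methoxyphenyl in place of 1,3-benzothiazol-2-yl on an amide-type nitrogen. The measured steps bearing on this position, the chloro for nitro change and the two exchanges of the amide aryl group, all run between limits; none gives a readable size in this assay, and the change to 4-methoxyphenyl stays within the same kind of aryl exchange. No step beyond the scatter is therefore expected, and the step from compound 3 to compound 4 is estimated as a step that the limit leaves unreadable from compound 3 to compound 4, most likely ending at the limit again.

For compound 4 the expected value in this assay is 700 ug/mL, with an estimated range from 350 ug/mL to 2000 ug/mL.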

Compound 4, half-maximal inhibitory concentration: > 500 ug/mL
Compound 4: only a limit was reported; the forecaster's own chance of this, stated with the estimate: 85%; the middle value lies beyond the limit too.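

In this assay compound 4 gives > 500 ug/mL, a limit of the assay and not a number. The steps joining compound 1, compound 2 and compound 3 to compound 4 cannot be read in size, because all four compounds share one limit: the limit of > 500 ug/mL in this assay, at which 4 of the 4 values shown sit.

The compounds shown leave open whether any exchange of the amide aryl group changes cytotoxicity in this assay.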